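Compound 1 to compound 4: one group exchanged

A few compounds are considered here, and "the series" means these few. Any claim that something is new, unique, unknown or untested is made for them only; others in the source may bear on it.

Three related compounds have so far been tested in a functional assay on DU-145 cells (Homo sapiens) for inhibition, read by trypan blue exclusion, with a stated time of 96 h; on this read-out lower numbers stand for stronger inhibition of growth and higher numbers for weaker inhibition of growth. Compound 1 (`Cc1cc(C)cc(/C=C(/SCc2ccc(F)cc2)C(=O)c2ccc(Br)cc2)c1`) gives 10000 nM, the highest number of the three and so the weakest inhibition of growth among them. Compound 2 (`O=C(/C(=C\c1c[nH]c2ccccc12)Sc1ccc(Br)cc1)c1ccc(Br)cc1`) gives 1000 nM, and compound 3 (`COc1ccc(S/C(=C/c2ccc(Cl)cc2Cl)C(=O)c2ccc(Br)cc2)cc1`) gives 1000 nM. Each of these two lies lower than compound 1 by a margin beyond the scatter. No two of the tested compounds differ in only one place, so their numbers do not show what any single group contributes.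

Compound 4 (`O=C(/C(=C\c1ccc2ccccc2n1)SCc1ccc(F)cc1)c1ccc(Br)cc1`) keeps the rest of compound 1 and changes one group, with quinolin-2-yl in place of 3,5-dimethylphenyl on a double-bonded chain carbon bound to a double-bonded chain carbon. With compound 1 at 10000 nM and compound 2 at 1000 nM, the tested compounds offer only a rough guide, and a move part of the way down that range seems the likeliest outcome. The estimated step is a 3.3-fold lower number from compound 1 to compound 4 (0.52 log units; beyond the scatter), in the direction of stronger inhibition of growth. In this assay the expected value for compound 4 is 3000 nM, with an estimated range of 600 nM to 10000 nM.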

Compound 4, concentration for 50% growth inhibition: 25000 nM
Estimate against measurement, compound 4: 8.3-fold (0.92 log units) below, and the stated range ends below it.
By their numbers in this assay, from the lowest: compounds 2 and 3 (each within the scatter of the next); then compound 1; then compound 4.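

In this assay, within the data shown here, compound 1 and compound 4 form the first pair that differs in only one place, so a single exchange can now be read on its own. On a double-bonded chain carbon bound to a double-bonded chain carbon, the exchange gives a 2.5-fold higher number from compound 1 to compound 4 (0.40 log units; beyond the scatter) and moves in the direction of weaker inhibition of growth, so this position is sensitive to the group it carries, and quinolin-2-yl, despite its extra ring and its hydrogen-bond acceptor, does not improve on 3,5-dimethylphenyl in this pair. No measurement is available that would explain this step.

The exchange adds a second ring and a ring nitrogen together, so it remains open which of these changes accounts for the step; naphthalen-2-yl, with two rings and no nitrogen, or pyridin-2-yl, with a nitrogen in a single ring, could separate them at this place. Going by these compounds, it also remains open whether the same exchange would have a similar effect on compounds that differ elsewhere, such as compound 2 and compound 3.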